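Amine end-group swap on a shared aryl ether core

The source may hold more compounds than are shown below. What is called first, only, known or untested is meant among the compounds shown, and "the series" means these compounds.

Three compounds share the core seen in compound 1 `COc1cc2c(Oc3ccc(NC(=O)c4nn(-c5ccccc5C)c(=O)cc4C)cc3F)ccnc2cc1OCCCN1CCC(C)CC1` and compound 2 `COc1cc2c(Oc3ccc(NC(=O)c4nn(-c5ccccc5C(F)(F)F)c(=O)cc4C)cc3F)ccnc2cc1OCCCN1CCC(C)CC1` and differ at the aryl group on the pyridazinone and at the amine ending the side chain. For the measured compounds named here, in a functional assay on HT-29 cells (Homo sapiens) for inhibition, read by MTT assay, with a stated time of 72 h (a lower number here means a stronger inhibitor, a higher number a weaker inhibitor), compound 1 gives 2810 nM and compound 2 gives 180 nM; the one measured step, a 16-fold lower number from compound 1 to compound 2 (1.19 log units; beyond the scatter), concerns only the aryl substituent. Compound 3 `COc1cc2c(Oc3ccc(NC(=O)c4nn(-c5cccc(F)c5)c(=O)cc4C)cc3F)ccnc2cc1OCCCN1CCCC1` carries a 3-fluorophenyl and a pyrrolidine end-group, and in this assay compound 3 gives 250 nM, the second highest of the three numbers, within the scatter of compound 2 and far below compound 1.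

Compound 4 `COc1cc2c(Oc3ccc(NC(=O)c4nn(-c5cccc(F)c5)c(=O)cc4C)cc3F)ccnc2cc1OCCCN1CCC(C)CC1` differs from compound 3 only at the chain terminus: 4-methylpiperidin-1-yl in place of pyrrolidin-1-yl on a saturated chain carbon, three bonds along the chain from an oxygen on an aromatic ring. Going by the values given here, no measured step touches this position, since compound 1 and compound 2 both already carry the 4-methylpiperidinyl group and differ elsewhere. Nothing in the data therefore points to a shift, and the expected step in this assay is no change at the digits printed from compound 3 to compound 4 (within the scatter), none beyond the scatter. Compound 4 is accordingly estimated at 250 nM, with a range from 100 nM to 650 nM.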

Compound 4, half-maximal inhibitory concentration: 300 nM
Compound 4: middle estimate off by 1.2-fold (0.08 log units), on the low side; the measured number falls inside the stated range.
By their numbers in this assay, from the lowest: compounds 2, 3 and 4 (each within the scatter of the next); then compound 1.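

In this assay, the change at the chain terminus, 4-methylpiperidin-1-yl in place of pyrrolidin-1-yl, gives a 1.2-fold higher number from compound 3 to compound 4 (0.08 log units; within the scatter), so with a 3-fluorophenyl on the aromatic nitrogen these two end-groups cannot be told apart. Compound 4 also allows the aryl group to be compared with the 4-methylpiperidin-1-yl end-group held constant: a 1.7-fold higher number from compound 2 to compound 4 (0.22 log units; within the scatter) contrasts with a 9.4-fold lower number from compound 1 to compound 4 (0.97 log units; beyond the scatter), which sets the 2-methylphenyl of compound 1 apart from both the 3-fluorophenyl and the 2-(trifluoromethyl)phenyl. No evidence is at hand to explain either result.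

The compounds shown leave open whether the end-group swap would read the same with a 2-methylphenyl or a 2-(trifluoromethyl)phenyl on the aromatic nitrogen, as the one pair here carries a 3-fluorophenyl. They also leave open how a morpholine or an N-methylpiperazine at the chain terminus would read, and whether a 2-(pyrrolidin-1-yl)ethyl chain would match the 3-(pyrrolidin-1-yl)propyl chain of compound 3.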